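Moving the fluorine on the aryl ring of compound 1

The source may report more compounds than this note shows. Statements on the series, on what has been measured and on what is new or still open speak of the compounds shown alone.

Among the measured compounds shown here, compound 1 `CC(C(=O)N1CCN(c2ccccc2F)CC1)N1C(=O)CCC1=O` stands highest of the two numbers so far in a functional assay on the whole organism (strain Swiss) with Mus musculus as the target, in the maximal electroshock model, with a stated time of 0.25 h (a lower number here means that less compound is needed, a higher number that more compound is needed for the effect), where compound 1 gives 151 mg/kg. Its nearest neighbour is compound 2 `CC(C(=O)N1CCN(c2ccccc2C(F)(F)F)CC1)N1C(=O)CCC1=O`, which in this assay gives 75.5 mg/kg; the step of a 2.0-fold lower number from compound 1 to compound 2 (0.30 log units; within the scatter) comes from trifluoromethyl in place of fluoro on an aromatic carbon. Compound 3 `CC(C(=O)N1CCN(c2cccc(F)c2)CC1)N1C(=O)CCC1=O` differs from compound 1 by 3-fluorophenyl in place of 2-fluorophenyl on an amine nitrogen in a ring. For the measured compounds named here, no measured step moves the fluorine along the ring; the only measured step changed the group on the ring and stayed within the scatter. With nothing that bears directly on this change, no step beyond the scatter is expected in this assay, and the expected step is a 1.2-fold lower number from compound 1 to compound 3 (0.07 log units; within the scatter). Compound 3 is therefore estimated at 130 mg/kg in this assay, with a range from 60 mg/kg to 300 mg/kg.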

Compound 3, dose for half-maximal effect: 137 mg/kg
Compound 3: the middle estimate sits 1.1-fold (0.02 log units) below what was measured; the measured number falls inside the stated range.
By their numbers in this assay, from the lowest: compounds 2, 3 and 1 (each within the scatter of the next).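

Unlike the step to compound 2, which replaced one group with another, this change keeps the same atoms and alters only where the fluorine sits on the phenyl ring. In this assay, 3-fluorophenyl in place of 2-fluorophenyl gives a 1.1-fold lower number from compound 1 to compound 3 (0.04 log units; within the scatter), so the two placements of fluorine cannot be told apart in this assay. No measured evidence bears on why these two compounds give such similar numbers.

The compounds shown leave open whether a chloro, methoxy or amine group on the phenyl ring would give a step beyond the scatter in this assay, and whether trifluoromethyl would behave as fluoro does when its place on the ring changes. They also leave open what a longer chain in place of the methyl group of the shared core would do.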